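Halogenated phenylamino swap: compound 2 to compound 3

The source may report more compounds than this note shows. Statements on the series, on what has been measured and on what is new or still open speak of the compounds shown alone.

Measured compounds:
compound 1 `Fc1ccc(Nc2nc(-c3cccc(F)c3)nc3ccc(F)cc23)cc1`
compound 2 `Fc1cccc(-c2nc(Nc3ccc(Cl)cc3)c3cc(F)ccc3n2)c1`

In a functional assay on HT29-AK cells (Homo sapiens) for cytotoxicity, read by MTT assay, with a stated time of 48 h (a higher number here means a weaker inhibitor, a lower number a stronger inhibitor), compound 1 returns > 50000 nM, which is a limit of the assay and not a number. In this assay compound 2 gives 40300 nM. The step of an at least 1.2-fold lower number from compound 1 to compound 2 (0.09 log units; that floor lies within the scatter) lies within the scatter, so the two cannot be ordered; compound 2 thus holds the only actual number shown, the other value being a limit (the limit of > 50000 nM in this assay, at which 1 of the 2 values shown sits).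

Compound 3 `Fc1cccc(-c2nc(Nc3cccc(Br)c3)c3cc(F)ccc3n2)c1` is not yet measured. It differs from compound 2 by 3-bromophenyl in place of 4-chlorophenyl on a nitrogen on an aromatic ring. Going by the values given here, the single measured step, an at least 1.2-fold lower number from compound 1 to compound 2 (0.09 log units; that floor lies within the scatter), also exchanged a halogen on this ring and stayed within the scatter, so it gives no ground for expecting movement beyond the scatter here. Compound 3 is therefore expected to give 38000 nM (range 12000 nM to 120000 nM), an estimated step of a 1.1-fold lower number from compound 2 to compound 3 (0.03 log units; within the scatter), with a real chance that this assay again reports only a limit.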

Compound 3, half-maximal inhibitory concentration: > 50000 nM
Compound 3 was reported as a limit; the forecaster's own chance of this, stated with the estimate: 35%; at least 1.3-fold (0.11 log units) between middle value and limit.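

In this assay, 3-bromophenyl in place of 4-chlorophenyl on the nitrogen gives an at least 1.2-fold higher number from compound 2 to compound 3 (0.09 log units; that floor lies within the scatter), so this exchange, which alters both the halogen and its place on the phenyl ring, produces no readable separation. The value of compound 3 is a limit of the assay and not a number, and the series now rests largely on such limits: the limit of > 50000 nM in this assay, at which 2 of the 3 values shown sit. The step between the two limits cannot be read, so the halogenated phenyl groups shown cannot be ranked against one another.

Open, from the compounds shown here alone, is whether any group on this phenyl ring moves the number beyond the scatter, for instance an amine or a carboxylic acid in place of the halogen. Also open, going by these compounds, is how the halogen and its place act separately, which 4-bromophenyl would address.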